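Moving a Methyl Group on the Phenyl Ring of Compound 1

The compounds below may be only part of what the source reports. "The series", "measured", "known", "first", "only" and "open" are said of these compounds alone.

Measured compounds:
compound 1, `CC(C)n1ncc2c(C(=O)NCc3cn(-c4ccccc4)nn3)cccc21`, 26000 nM
compound 2, `CC(C)n1ncc2c(C(=O)NCc3cn(-c4ccc(F)cc4)nn3)cccc21`, > 40000 nM
compound 3, `Cc1ccc(-n2cc(CNC(=O)c3cccc4c3cnn4C(C)C)nn2)cc1`, 39000 nM

In a functional assay on PC-3 cells (Homo sapiens) for inhibition, read by MTT assay, with a stated time of 72 h (a higher number here means a weaker inhibitor, a lower number a stronger inhibitor), compound 1 gives 26000 nM, the lowest of the two numbers shown, and compound 3 sits a short way away with a 1.5-fold higher number from compound 1 to compound 3 (0.18 log units; within the scatter), a gap within the scatter. Compound 2 reports only a limit in this assay, > 40000 nM; that limit is the limit of > 40000 nM in this assay, at which 1 of the 3 values shown sits.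

Compound 4, `Cc1cccc(-n2cc(CNC(=O)c3cccc4c3cnn4C(C)C)nn2)c1`, is the compound still to be measured. It differs from compound 1 in one place: methyl in place of hydrogen on an aromatic carbon. Within the data shown here, the change is thus the same kind as the one from compound 1 to compound 3, methyl in place of hydrogen on an aromatic carbon, but at a different carbon of the phenyl ring.

Among the measured compounds shown here, two measured steps bear on this. The step of a 1.5-fold higher number from compound 1 to compound 3 (0.18 log units; within the scatter) stayed within the scatter, and the step of an at least 1.5-fold higher number from compound 1 to compound 2 (0.18 log units; that floor lies within the scatter) reached only the limit. Neither points to a clear shift in this assay, so no step beyond the scatter is expected for compound 4, with a slight lean toward a higher number.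

Compound 4 is therefore expected to show 33000 nM in this assay, between 15000 nM and 70000 nM, which means the expected step of a 1.3-fold higher number from compound 1 to compound 4 (0.10 log units; within the scatter).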

Compound 4, half-maximal inhibitory concentration: 32300 nM
Beside the measured number, compound 4's estimate is 1.0-fold (0.01 log units) above it, and the stated range covers the measured number.
By their numbers in this assay, from the lowest: compounds 1, 4 and 3 (each within the scatter of the next). At a limit, above all of these: compound 2.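

Compound 4 shows that a methyl group placed meta to a large group on the phenyl ring also leaves the number in this assay inside the scatter, with a 1.2-fold higher number from compound 1 to compound 4 (0.09 log units; within the scatter). Among these compounds, the earlier compounds held a methyl group at only one carbon of this ring, and the new compound allows a direct comparison of two placements, which gives a 1.2-fold lower number from compound 3 to compound 4 (0.08 log units; within the scatter), so moving the methyl group makes no readable difference here. The comparison with the 4-fluorophenyl compound gives only a floor, an at least 1.2-fold lower number from compound 2 to compound 4 (0.09 log units; that floor lies within the scatter), and its starting value is a limit of the assay rather than a number: the limit of > 40000 nM in this assay, at which 1 of the 4 values shown sits.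

Only hydrogen, methyl and fluoro appear on this phenyl ring among the compounds shown, so what an amine, a carboxylic acid or a longer chain on the same ring would do in this assay remains open. Also open, on these data alone, is whether any change to this ring can carry the number beyond the scatter at all, since every step that can be read here stays within it.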